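The compounds below may be only part of what the source reports. "The series", "measured", "known", "first", "only" and "open" are said of these compounds alone.

Compound 1 `O=S(=O)(NCCCNCc1ccccc1Cl)c1cc(C(F)(F)F)cc(C(F)(F)F)c1` carries a 2-chlorobenzyl group on the amine nitrogen of the shared core. For the measured compounds named here, in a functional assay on A2780 cells (Homo sapiens) for inhibition, read by MTT assay, with a stated time of 72 h (on this read-out higher numbers stand for weaker inhibition of growth and lower numbers for stronger inhibition of growth), compound 1 gives 9300 nM, the highest of the three numbers measured so far. Compound 2 `CC(C)(C)c1ccc(CNCCCNS(=O)(=O)c2cc(C(F)(F)F)cc(C(F)(F)F)c2)cc1` gives 2900 nM in this assay, and compound 3 `O=S(=O)(NCCCNCC1COc2ccccc2O1)c1cc(C(F)(F)F)cc(C(F)(F)F)c1` gives 1500 nM. The two steps away from compound 1 are a 3.2-fold lower number from compound 1 to compound 2 (0.51 log units; beyond the scatter) and a 6.2-fold lower number from compound 1 to compound 3 (0.79 log units; beyond the scatter); between the other two the step is a 1.9-fold lower number from compound 2 to compound 3 (0.29 log units; within the scatter).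

Compound 4 `CN(CCCNS(=O)(=O)c1cc(C(F)(F)F)cc(C(F)(F)F)c1)Cc1ccccc1` differs from compound 1 in one place: benzyl(methyl)amino in place of (2-chlorobenzyl)amino on a saturated chain carbon, three bonds along the chain from a sulfonamide nitrogen. The two measured steps out of compound 1 both replaced the 2-chlorophenyl group with a different ring and both gave modestly lower numbers, so they point to the 2-chlorophenyl group as the weakest of the options tried. Going by the values given here, neither of them removed only the chlorine, and none of the measured compounds carries a methyl on the amine nitrogen, so the present change is only partly covered. A modest step in this assay is expected, most likely toward a lower number, but with wide uncertainty. Compound 4 is therefore expected to give about 6000 nM, within a range from 2000 nM to 18000 nM. The step this estimate implies is a 1.6-fold lower number from compound 1 to compound 4 (0.19 log units; within the scatter).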

Compound 4, concentration for 50% growth inhibition: 28000 nM
Compound 4: the middle estimate sits 4.7-fold (0.67 log units) below what was measured, and the stated range ends below it.
By their numbers in this assay, from the lowest: compounds 3 and 2 (each within the scatter of the next); then compound 1; then compound 4.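

Replacing (2-chlorobenzyl)amino with benzyl(methyl)amino on a saturated chain carbon, three bonds along the chain from a sulfonamide nitrogen, gives a 3.0-fold higher number from compound 1 to compound 4 (0.48 log units; beyond the scatter) in this assay, the first step out of compound 1 at this position that goes to a higher number. Compound 1 therefore no longer marks the top of the range at this position, and the result shows that a change here can weaken inhibition of growth as well as strengthen it. The change also differs in kind from the earlier steps: the entering group keeps a six-membered aromatic ring of carbon only, loses the chlorine, gains a methyl and goes from 1 hydrogen-bond donor to 0, and nothing measured here explains the higher number.

The chlorine and the methyl changed together, so this single step cannot show how much of the rise belongs to each. On these data alone, a benzylamino group would isolate the loss of the chlorine, and a (2-chlorobenzyl)(methyl)amino group would isolate the added methyl, so the contribution of each remains open.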